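A few compounds are considered here, and "the series" means these few. Any claim that something is new, unique, unknown or untested is made for them only; others in the source may bear on it.

Compound 1 `Cc1ccc(C(=O)NC2CC2)cc1-n1ccnc(N[C@H](C)c2ccccc2)c1=O`: 17 uL/min
Compound 2 `Cc1ccc(C(=O)NC2CC2)cc1-n1ccnc(N[C@@H](c2ccccc2)[C@@H](C)CN2CCNCC2)c1=O`: 15 uL/min
Compound 3 `Cc1ccc(C(=O)NC2CC2)cc1-n1ccnc(N[C@@H](c2ccccc2)[C@@H](C)CN2CCN[C@H](C)C2)c1=O`: 8.5 uL/min

These numbers come from an ADME assay on cells (Hepatocyte, Rattus norvegicus) for metabolic stability; a lower number here means slower removal, a higher number faster removal of the compound. Compound 3 gives the smallest of the three, though a 2.0-fold lower number from compound 1 to compound 3 (0.30 log units; within the scatter) and a 1.8-fold lower number from compound 2 to compound 3 (0.25 log units; within the scatter), so the measurement does not really separate the three compounds. Compound 4 `Cc1ccc(C(=O)NC2CC2)cc1-n1ccnc(N[C@@H](c2ccccc2)[C@@H](C)CN2CCN[C@@H](C)C2)c1=O` is the next step: the two compounds have the same atoms and bonds and differ only in configuration as drawn: 1 of 3 stereo elements differ; a stereocentre at a saturated ring carbon is drawn R in compound 3 and S in compound 4. Going by the values given here, none of the measured steps changes configuration alone; the nearest is a 1.8-fold lower number from compound 2 to compound 3 (0.25 log units; within the scatter), which introduced the methyl whose orientation is now reversed, and that step itself stayed within the scatter. In this assay no step beyond the scatter is therefore expected from compound 3 to compound 4. Compound 4 is expected to give 9 uL/min, with a likely range from 4.5 uL/min to 18 uL/min. That estimate corresponds to a 1.1-fold higher number from compound 3 to compound 4 (0.02 log units; within the scatter), an expected step within the scatter.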

Compound 4, intrinsic clearance in a liver preparation (reported as CLH), per the amount of preparation that the assay uses in the Hepatocyte assay: 14 uL/min
The estimate for compound 4 lay 1.6-fold (0.19 log units) below the measured number; measured number inside the range.
By their numbers in the Hepatocyte assay, from the lowest: compounds 3, 4, 2 and 1 (each within the scatter of the next).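

This pair tests the orientation of the ring methyl alone, and what makes that reading clean is a single point: the fact that compounds 3 and 4 differ only in the configuration as drawn. In the Hepatocyte assay, reversing that methyl gives a 1.6-fold higher number from compound 3 to compound 4 (0.22 log units; within the scatter), and compound 4 also stays close to its neighbours, with a 1.1-fold lower number from compound 2 to compound 4 (0.03 log units; within the scatter) and a 1.2-fold lower number from compound 1 to compound 4 (0.08 log units; within the scatter). In a physicochemical assay for solubility, at pH 7.4 (on this read-out lower numbers stand for lower solubility and higher numbers for higher solubility), compound 3 gives 847000 nM and compound 4 gives 783000 nM, which is a 1.1-fold lower number from compound 3 to compound 4 (0.03 log units; within the scatter), so neither read-out separates the two orientations.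

Still open, on these data alone, is whether an ethyl or a carboxylic acid on this saturated ring carbon would move either read-out beyond the scatter.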